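Chloro to bromo on the acetyl compound

The source may report more compounds than this note shows. Statements on the series, on what has been measured and on what is new or still open speak of the compounds shown alone.

Compound 1 (`O=C(Nc1ccc(C(F)(F)F)cc1)c1cc(Cl)ccc1O`) gives 2200 nM
Compound 2 (`CC(=O)c1ccc(NC(=O)c2cc(Cl)ccc2O)cc1`) gives 16100 nM

In a functional assay on MONO-MAC-6 cells (Homo sapiens) for cytotoxicity, read by MTT assay, with a stated time of 24 h (on this read-out higher numbers stand for weaker inhibition and lower numbers for stronger inhibition), compound 2 holds the higher of the two numbers. Going by the values given here, its gap to the only other measured compound is also the one measured step, a 7.3-fold higher number from compound 1 to compound 2 (0.86 log units; beyond the scatter) with acetyl in place of trifluoromethyl on an aromatic carbon.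

Compound 3 (`CC(=O)c1ccc(NC(=O)c2cc(Br)ccc2O)cc1`) keeps the acetyl. The change is bromo in place of chloro on an aromatic carbon on an aromatic carbon para to a hydroxy group. The measured step concerns a different place in the molecule, so the data give no size for a change at this one. No step beyond the scatter is therefore expected in this assay in either direction. The estimated step is a 1.2-fold lower number from compound 2 to compound 3 (0.06 log units; within the scatter) and remains inside the scatter. The estimate for compound 3 is 14000 nM (expected range 6000 nM to 30000 nM).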

Compound 3, half-maximal inhibitory concentration: 18600 nM
Compound 3: the middle estimate sits 1.3-fold (0.12 log units) below what was measured; the range from low to high includes it.
By their numbers in this assay, from the lowest: compound 1; then compounds 2 and 3 (each within the scatter of the next).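

In this assay, bromo in place of chloro on the aromatic carbon para to a hydroxy group comes with a 1.2-fold higher number from compound 2 to compound 3 (0.06 log units; within the scatter), which gives this position its first measured step. With the acetyl kept, chloro and bromo read alike here, so this exchange does not touch the larger difference seen on the other side of the amide, a 7.3-fold higher number from compound 1 to compound 2 (0.86 log units; beyond the scatter). No measurement shown bears on why the two halogens read alike.

Whether the same exchange reads alike with trifluoromethyl in place of acetyl remains open, since compound 1 has no bromo partner among the compounds shown. Also open, as far as these compounds go, is how far this position tolerates something other than a halogen, such as an amine, a methoxy group or a carboxylic acid.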